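Dropping the fluoro group from the weaker enantiomer

The compounds below may be only part of what the source reports. "The series", "measured", "known", "first", "only" and "open" are said of these compounds alone.

Two mirror-image compounds share one core. Compound 1 `OC[C@@]1(c2ccc(F)cc2)NC[C@@H](O)[C@@H]1O` and compound 2 `OC[C@]1(c2ccc(F)cc2)NC[C@H](O)[C@H]1O` carry the same atoms and bonds and differ only in configuration, all three stereocentres being inverted. In an assay on isolated protein for inhibition of lysosomal alpha-glucosidase (Rattus norvegicus), read by colorimetric assay (on this read-out lower numbers stand for stronger inhibition and higher numbers for weaker inhibition), compound 1 gives 12000 nM. Compound 2 in this assay gives 101000 nM, the higher of the two numbers, and the gap between them is an 8.4-fold higher number from compound 1 to compound 2 (0.93 log units; beyond the scatter), a difference that rests on (the fact that compounds 1 and 2 differ only in the configuration as drawn).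

Compound 3 `OC[C@]1(c2ccccc2)NC[C@H](O)[C@H]1O` is built from compound 2 by a single change at the aromatic ring: hydrogen in place of fluoro on an aromatic carbon. Within the data shown here, no measured pair speaks to this change; the only step seen so far, an 8.4-fold higher number from compound 1 to compound 2 (0.93 log units; beyond the scatter), concerns configuration and leaves the aryl substituent untouched. With nothing to point one way or the other, the expected step in this assay is none beyond the scatter. Compound 3 is therefore estimated to give about 100000 nM, with a range from 30000 nM to 330000 nM, which would mean a 1.0-fold lower number from compound 2 to compound 3 (0.00 log units; within the scatter).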

Compound 3, half-maximal inhibitory concentration: 190 nM
Estimate against measurement, compound 3: 530-fold (2.72 log units) above, outside the stated range (below it).
By their numbers in this assay, from the lowest: compound 3; then compound 1; then compound 2.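

In this assay, the aromatic carbon para to a group of 9 heavy atoms proves to be a very sensitive place in this series: hydrogen in place of fluoro, a change of one heavy atom that involves no ring, no net charge and no hydrogen-bond donor or acceptor, gives a 530-fold lower number from compound 2 to compound 3 (2.73 log units; beyond the scatter) and so turns a weak compound into a much stronger one. That large step clearly exceeds an 8.4-fold higher number from compound 1 to compound 2 (0.93 log units; beyond the scatter) as the only other step shown, so among these compounds the single fluoro group moves the number further than inverting all three stereocentres does. What is known about these compounds concerns only their configuration and offers no explanation for the effect of removing the fluoro group.

The compounds shown leave open whether hydrogen in place of fluoro has a comparable effect on compound 1, the mirror image of compound 2, so the size of this step may belong to one enantiomer only. They also leave open how chloro, methyl or methoxy at the same aromatic carbon would compare with fluoro and hydrogen.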